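The source may hold more compounds than are shown below. What is called first, only, known or untested is meant among the compounds shown, and "the series" means these compounds.

Measured so far in a functional assay on HCT-116 cells (Homo sapiens) for cytotoxicity, read by MTT assay, with a stated time of 72 h (a lower number here means a stronger inhibitor, a higher number a weaker inhibitor), all three as limits:
Compound 1 `O=C(NCc1ccc(F)cc1)c1nc(Br)c2cccnc2c1NCCO`: > 20000 nM
Compound 2 `NCCNc1c(C(=O)NCc2ccc(F)cc2)nc(Br)c2cccnc12`: > 20000 nM
Compound 3 `O=C(NCc1ccc(F)cc1)c1nc(Br)c2cccnc2c1N1CCNCC1`: > 10000 nM

Compound 3 has no number in this assay, only the limit > 10000 nM, and the other two compounds are likewise known only by limits. Compound 4 `Cc1ccc(S(=O)(=O)Oc2c(C(=O)NCc3ccc(F)cc3)nc(Br)c3cccnc23)cc1` is the next to be read. It carries ((4-methylphenyl)sulfonyl)oxy in place of piperazin-1-yl on an aromatic carbon, para to a bromo group: ((4-methylphenyl)sulfonyl)oxy in place of piperazin-1-yl on an aromatic carbon.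

Among the compounds with values here, three measured steps bear on this change: a step that the two limits leave unreadable from compound 1 to compound 2, a step that the two limits leave unreadable from compound 1 to compound 3 and a step that the two limits leave unreadable from compound 2 to compound 3. None of them has a readable size, and none brings in ((4-methylphenyl)sulfonyl)oxy, so no size can be carried over. The expectation therefore rests on compound 3 and its limit of > 10000 nM. No step beyond the scatter is expected in either direction, and the expected step is a step that the limit leaves unreadable from compound 3 to compound 4. For compound 4 the estimated value is 15000 nM. The expected range for compound 4 runs from 5000 nM to 30000 nM.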

Compound 4, half-maximal inhibitory concentration: > 20000 nM
Compound 4: a limit, no number (the forecaster's own chance of this, stated with the estimate: 65%); middle value at least 1.3-fold (0.12 log units) from the limit.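

In this assay compound 4 gives > 20000 nM, a limit and not a number. Within the data shown here, no step to it from compound 1, compound 2 or compound 3 can be read. The compounds shown leave open how the groups on this aromatic carbon rank against one another in this assay.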